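The source may hold more compounds than are shown below. What is called first, only, known or untested is meant among the compounds shown, and "the series" means these compounds.

Working notes on the series. Compound 1 `Cc1cccc(Cn2cc(C(N)=O)c3c(N)ncnc32)c1` carries a carboxamide on the shared core. In a functional assay on KB cells (Homo sapiens) for cytotoxicity (a higher number here means a weaker inhibitor, a lower number a stronger inhibitor), compound 1 gives > 100000 nM, which is a limit of the assay and not a number (the limit of > 100000 nM in this assay, at which 1 of the 3 values shown sits). Compound 2 `Cc1cccc(Cn2cc(C(=N)S)c3c(N)ncnc32)c1` replaces that carboxamide with a thioamide; in this assay compound 2 gives 30000 nM. Compound 3 `N#Cc1c[nH]c2ncnc(N)c12` is a smaller analogue of the core bearing a nitrile; in this assay compound 3 gives 18000 nM.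

Going by the values given here, the one measured step, an at least 3.3-fold lower number from compound 1 to compound 2 (0.52 log units; beyond the scatter), touches the carboxamide and says nothing about the methylphenyl group. The change from compound 1 to compound 4 `Cc1ccc(Cn2cc(C(N)=O)c3c(N)ncnc32)cc1` is 4-methylphenyl in place of 3-methylphenyl on a saturated chain carbon bound to an aromatic nitrogen. Among the compounds with values here, no measured step bears on this change, so there is no basis for expecting a step beyond the scatter in this assay in either direction; compound 1 stands at the limit, and compound 4 is expected to remain near it.

Compound 4 is therefore estimated at 150000 nM, with a range from 40000 nM to 600000 nM, an expected step that the limit leaves unreadable from compound 1 to compound 4.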

Compound 4, half-maximal inhibitory concentration: > 100000 nM
Compound 4 was reported as a limit; the forecaster's own chance of this, stated with the estimate: 70%; the middle value does not contradict the limit.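

In this assay compound 4 gives > 100000 nM, which is a limit of the assay and not a number. Compound 1 stands at the same limit, so the step to compound 4 cannot be read. The compounds shown leave open whether 4-methylphenyl in place of 3-methylphenyl changes the read-out at all.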